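Isopropyl in place of a hydroxyhexyl chain at the aryl ether

The compounds below may be only part of what the source reports. "The series", "measured", "known", "first", "only" and "open" are said of these compounds alone.

Compound 1, `O=C(O)CCCCOc1ccc2c(=O)c(-c3ccc(O)cc3)coc2c1`, in an assay (Cricetulus griseus) for inhibition of Monoamine oxidase (Homo sapiens) (on this read-out higher numbers stand for weaker inhibition and lower numbers for stronger inhibition), gives compound 1 a value of 5000 nM.
Compound 2, `NCCCCOc1ccc2c(=O)c(-c3ccc(O)cc3)coc2c1`, gives only a limit of the assay, > 9000 nM.
Compound 3, `O=c1c(-c2ccc(O)cc2)coc2cc(OCCCCCCO)ccc12`, likewise gives only a limit of the assay, > 9000 nM.

Compound 3 therefore stands at the assay limit, (the limit of > 9000 nM in this assay, at which 2 of the 3 values shown sit), and no number is known for it. The steps that touch it are an at least 1.8-fold higher number from compound 1 to compound 3 (0.25 log units; that floor lies within the scatter) and, for the related pair, an at least 1.8-fold higher number from compound 1 to compound 2 (0.25 log units; that floor lies within the scatter); both floors lie within the scatter. The step that the two limits leave unreadable from compound 2 to compound 3 cannot be read, since both ends are limits.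

Compound 4, `CC(C)Oc1ccc2c(=O)c(-c3ccc(O)cc3)coc2c1`, differs from compound 3 by isopropyl in place of 6-hydroxyhexyl on an oxygen on an aromatic ring. Going by the values given here, no measured step covers a change of this kind: every measured step alters only the end group of a long chain. Starting from a limit, the size of the step of an at least 2.2-fold lower number from compound 3 to compound 4 (0.35 log units; beyond the scatter) is expected, but with little support. For compound 4 in this assay the estimate is 4000 nM, within a range from 1000 nM to 20000 nM.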

Compound 4, half-maximal inhibitory concentration: 200 nM
The estimate for compound 4 lay 20-fold (1.30 log units) above the measured number; the whole stated range lies above it.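

Going by these compounds alone, at this position, on an oxygen on an aromatic ring, isopropyl gives the only large steps in this assay: an at least 45-fold lower number from compound 3 to compound 4 (1.65 log units; beyond the scatter), an at least 45-fold lower number from compound 2 to compound 4 (1.65 log units; beyond the scatter) and a 25-fold lower number from compound 1 to compound 4 (1.40 log units; beyond the scatter). The earlier readable steps changed only the end group of a long chain and had floors within the scatter, whereas all three new steps lie beyond it, so compound 4 separates from compound 1, compound 2 and compound 3 whichever end group the chain carries. Two of these steps are floors rather than full sizes: the limit of > 9000 nM in this assay, at which 2 of the 4 values shown sit.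

Isopropyl differs from the long chains in both length and end group, so the compounds shown do not separate these two changes. From the compounds shown here alone, how a plain hexyl chain, a straight propyl chain or a methyl group would read at this oxygen remains open.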